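Extending the Carbamate Chain of Compound 2

This account rests on a few compounds, and the source may have more. Where it says the series, first, only, none or still open, it means among the compounds named here.

Compound 1 `CCC(CC)C(=O)OCC1CN(Cc2cc(OC)c(OC)c(OC)c2)CCN1Cc1cc(OC)c(OC)c(OC)c1`: 2700 nM
Compound 2 `CCCCNC(=O)OCC1CN(C(=O)c2cc(OC)c(OC)c(OC)c2)CCN1C(=O)c1cc(OC)c(OC)c(OC)c1`: 240 nM

In a functional assay (Oryctolagus cuniculus) for inhibition of platelet-activating factor receptor (Cavia porcellus) (on this read-out lower numbers stand for stronger inhibition and higher numbers for weaker inhibition), compound 2 gives the lower of the two numbers shown, and compound 1 gives a higher one, a gap beyond the scatter. Compound 3 `CCCCCCCCNC(=O)OCC1CN(C(=O)c2cc(OC)c(OC)c(OC)c2)CCN1C(=O)c1cc(OC)c(OC)c(OC)c1` differs from compound 2 by butyl in place of hydrogen on a saturated chain carbon, four bonds along the chain from an amide-type nitrogen. Within the data shown here, no measured pair differing in one place is available here, so the size of such a step cannot be read from these data. In this assay the change is expected to move the number only modestly, if at all. Compound 3 is expected to give 150 nM, within a range from 40 nM to 800 nM. The step is estimated as a 1.6-fold lower number from compound 2 to compound 3 (0.20 log units; within the scatter).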

Compound 3, half-maximal inhibitory concentration: 370 nM
Compound 3: middle estimate off by 2.5-fold (0.39 log units), on the low side; low and high end bracket the measured number.
By their numbers in this assay, from the lowest: compounds 2 and 3 (each within the scatter of the next); then compound 1.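

In this assay, among these compounds, the step of a 1.5-fold higher number from compound 2 to compound 3 (0.19 log units; within the scatter) is the first one read at this position, and it shows that butyl can replace hydrogen here without moving the number beyond the usual scatter. The chain can therefore grow by this much with no measurable gain or loss of inhibition. Nothing available here offers an explanation for this result.

Still open, as far as these compounds go, is whether a longer chain would also leave the number unchanged. Equally open, from the compounds shown here alone, is what an amine or a carboxylic acid in place of butyl at this position would do.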